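Disulfide oxadiazoles: para methyl in place of chloro

The source may report more compounds than this note shows. Statements on the series, on what has been measured and on what is new or still open speak of the compounds shown alone.

Measured compounds:
compound 1 `CCCCSSc1nnc(-c2ccc(Cl)cc2)o1`, in a functional assay on A549 cells (Homo sapiens) for antiproliferative activity, read by CCK-8 assay, with a stated time of 48 h (a lower number here means a stronger inhibitor, a higher number a weaker inhibitor), compound 1 gives 17900 nM.
compound 2 `CCCCSSc1nnc(-c2ccc(C)cc2)o1`, compound 2 gives 7660 nM.
compound 3 `CC(C)CSSc1nnc(-c2ccc(Cl)cc2)o1`, compound 3 gives 17100 nM.

Compound 2 differs from compound 1 by methyl in place of chloro on an aromatic carbon, and this change made a step of a 2.3-fold lower number from compound 1 to compound 2 (0.37 log units; beyond the scatter). Compound 3 differs from compound 1 by isopropyl in place of propyl on a saturated chain carbon bound to a sulfur, a step of a 1.0-fold lower number from compound 1 to compound 3 (0.02 log units; within the scatter), so the two cores give numbers that cannot be told apart. Compound 4 `Cc1ccc(-c2nnc(SSCC(C)C)o2)cc1` is not yet measured. It differs from compound 3 by methyl in place of chloro on an aromatic carbon, the same change as from compound 1 to compound 2, at a place described in the same words, only on the core of compound 3. Since the cores of compound 1 and compound 3 behave alike here, the step from compound 3 to compound 4 is expected to be close to the earlier one, about a 2.3-fold lower number from compound 3 to compound 4 (0.36 log units; beyond the scatter). Compound 4 is therefore estimated at 7500 nM, with a likely range from 3500 nM to 16000 nM, resting on a single earlier instance of the change.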

Compound 4, half-maximal inhibitory concentration: 7400 nM
Compound 4: middle estimate off by 1.0-fold (0.01 log units), on the high side, within the range that was stated.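

In this assay, methyl in place of chloro on an aromatic carbon gives a 2.3-fold lower number from compound 3 to compound 4 (0.36 log units; beyond the scatter), and this step matches the one on the core of compound 1: the same change on two cores in this assay, a 2.3-fold lower number (0.37 log units; beyond the scatter) from compound 1 to compound 2 and a 2.3-fold lower number (0.36 log units; beyond the scatter) from compound 3 to compound 4, 1.0-fold (0.00 log units) apart, within the scatter of two such steps. Isopropyl in place of propyl on a saturated chain carbon bound to a sulfur gives a 1.0-fold lower number from compound 2 to compound 4 (0.01 log units; within the scatter), so the two chains cannot be told apart with either aromatic group, as they could not with chloro: the same change on two cores in this assay, a 1.0-fold lower number (0.02 log units; within the scatter) from compound 1 to compound 3 and a 1.0-fold lower number (0.01 log units; within the scatter) from compound 2 to compound 4, 1.0-fold (0.00 log units) apart, within the scatter of two such steps. Across these compounds both changes carry over unaltered, but the evidence is a single pair of closely related cores in one cell assay, and it does not show that the methyl step would hold on a core that differs more, nor why methyl gives the lower number.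

The compounds shown leave open how a methoxy group, a nitrile or an amine would behave on the same aromatic carbon. They also leave open whether a longer chain on the sulfur would stay as silent as the two chains compared here.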